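The compounds below may be only part of what the source reports. "The series", "measured", "known", "first", "only" and "open" are said of these compounds alone.

For the measured compounds named here, compound 1, `CCCc1ccc(Nc2nccs2)cc1OCC=C(C)C`, holds the higher of the two numbers so far recorded in a functional assay on MT2 cells (Homo sapiens) for cytotoxicity (on this read-out higher numbers stand for lower toxicity in this test and lower numbers for higher toxicity in this test), where compound 1 gives 23000 nM. Going by the values given here, compound 2, `CC(C)=CCOc1cc(Nc2nccc(C(F)(F)F)n2)ccc1Cl`, gives 2500 nM in this assay, a lower number that lies beyond the usual scatter of repeated runs; the two structures differ in several places at once, so the pair shows only that compound 1 stands higher and compound 2 lower. Compound 3, `CCc1ccc(Nc2nccs2)cc1OCC=C(C)C`, has not yet been measured in this assay. It differs from compound 1 in a single place: hydrogen in place of methyl on a saturated chain carbon, two bonds along the chain from an aromatic carbon. Among the compounds with values here, no step between measured compounds of this kind is available to guide the expectation, so the change is judged on its own modest size. The step to be expected is small, a 1.2-fold higher number from compound 1 to compound 3 (0.09 log units; within the scatter), leaning if anything toward a higher number and quite possibly falling within the scatter. Compound 3 is therefore expected to give about 28000 nM in this assay, with a plausible range from 12000 nM to 65000 nM.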

Compound 3, half-maximal cytotoxic concentration: 31000 nM
Estimate against measurement, compound 3: 1.1-fold (0.04 log units) below, and the stated range covers the measured number.
By their numbers in this assay, from the lowest: compound 2; then compounds 1 and 3 (each within the scatter of the next).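

Compound 3 gives the series its first reading of a change in one place: in this assay, going from propyl to ethyl, with hydrogen in place of methyl on a saturated chain carbon, two bonds along the chain from an aromatic carbon, gives a 1.3-fold higher number from compound 1 to compound 3 (0.13 log units; within the scatter) and so leaves the two compounds indistinguishable on this read-out. Removing this one carbon from the end of the chain on the core of compound 1 therefore has no effect that can be told apart from the ordinary spread of repeated runs, and the outermost methyl of the propyl group is not shown to matter in this test. No measurement at hand offers an explanation for this outcome.

What the compounds shown leave open is whether a shorter substituent such as methyl, a longer chain such as butyl, or an amine or a carboxylic acid at the end of the chain would produce a step beyond the scatter. This single pair also leaves open whether the same change would read alike on a different core, such as that of compound 2.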